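This account rests on a few compounds, and the source may have more. Where it says the series, first, only, none or still open, it means among the compounds named here.

Of the compounds shown here, three built on a shared core have so far been measured in a functional assay on Mahlavu cells (Homo sapiens) for antiproliferative activity, read by sulforhodamine B assay, with a stated time of 72 h; a higher number here means a weaker inhibitor, a lower number a stronger inhibitor. Compound 1 `FC(F)(F)c1ccc(CN2CCN(Cc3cc(-c4ccc(OCc5ccccc5Cl)cc4)on3)CC2)cc1` gives 3200 nM, and compound 2 `FC(F)(F)c1ccc(CN2CCN(Cc3cc(-c4ccc(OCc5ccc(Cl)cc5)cc4)on3)CC2)cc1` gives 3700 nM; the step of a 1.2-fold higher number from compound 1 to compound 2 (0.06 log units; within the scatter) stays within the scatter. Compound 3 `N#Cc1cccc(COc2ccc(-c3cc(CN4CCN(Cc5ccc(C(F)(F)F)cc5)CC4)no3)cc2)c1` gives 10600 nM, the highest number of the three, since both a 3.3-fold higher number from compound 1 to compound 3 (0.52 log units; beyond the scatter) and a 2.9-fold higher number from compound 2 to compound 3 (0.46 log units; beyond the scatter) lie beyond the scatter.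

Compound 4 `Cc1cc(OCc2cccc(C#N)c2)ccc1-c1cc(CN2CCN(Cc3ccc(C(F)(F)F)cc3)CC2)no1` differs from compound 3 by methyl in place of hydrogen on an aromatic carbon. Going by the values given here, none of the measured steps touches this position; all three change the group on the saturated chain carbon bound to the ring oxygen, so no measured step bears directly on the change. The author therefore expects no step beyond the scatter, the estimated step being a 1.1-fold lower number from compound 3 to compound 4 (0.03 log units; within the scatter). Compound 4 is estimated at 10000 nM, within a range from 4000 nM to 25000 nM.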

Compound 4, half-maximal inhibitory concentration: 500 nM
The estimate for compound 4 lay 20-fold (1.30 log units) above the measured number; measured number below the stated range.
By their numbers in this assay, from the lowest: compound 4; then compounds 1 and 2 (each within the scatter of the next); then compound 3.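

In this assay, going by these compounds alone, a single methyl in place of hydrogen gives a 21-fold lower number from compound 3 to compound 4 (1.33 log units; beyond the scatter), a larger step than any seen among the earlier compounds, which differ only in the group on the chain carbon bound to the ring oxygen. This shows that the aromatic carbon ortho to a large group and meta to a (3-cyanobenzyl)oxy group is a position where one added carbon can change the number strongly. Nothing measured here explains the size of this step.

On these data alone, it remains open whether methyl at this carbon gives a similar step with the 2-chlorophenyl or 4-chlorophenyl group of compound 1 or compound 2. Also open, as far as these compounds go, is how an ethyl group, a methoxy group or a chlorine atom at the same carbon would compare.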